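Benzamido to nitro: growth inhibition notes

The source may report more compounds than this note shows. Statements on the series, on what has been measured and on what is new or still open speak of the compounds shown alone.

In a functional assay on ACHN cells (Homo sapiens) for inhibition, read by sulforhodamine B assay (a lower number here means a stronger inhibitor of growth, a higher number a weaker inhibitor of growth), the entry for compound 1 `O=C(CCC1=CCCN(Cc2ccc(F)cc2)C1=O)NO` reads "not determined" (no result reported). Compound 2 `COc1ccc(CN2CCC=C(CCC(=O)NO)C2=O)cc1` gives 1670 nM. Compound 3 `O=C(CCC1=CCCN(Cc2ccc(NC(=O)c3ccccc3)cc2)C1=O)NO` gives > 10000 nM, which is a limit of the assay and not a number. This is the limit of > 10000 nM in this assay, at which 1 of the 3 values shown sits.

Compound 4 `O=C(CCC1=CCCN(Cc2ccc([N+](=O)[O-])cc2)C1=O)NO` carries nitro in place of benzamido on an aromatic carbon, para to a large group: nitro in place of benzamido on an aromatic carbon.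

For the measured compounds named here, only one measured step bears on this change. Benzamido in place of methoxy gave an at least 5.9-fold higher number from compound 2 to compound 3 (0.77 log units; beyond the scatter), which lies beyond the scatter. Compound 4 also loses benzamido, so that step, read in reverse, points to a lower number in this assay. Nitro is not methoxy, however, so compound 2 at 1670 nM serves only as a rough guide. Compound 4 may also return a limit of the assay. The expected change is an at least 4.0-fold lower number from compound 3 to compound 4 (0.60 log units; beyond the scatter), beyond the scatter if a number is reported. For compound 4 the estimated value is 2500 nM, with an expected range of 800 nM to 9000 nM.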

Compound 4, concentration for 50% growth inhibition: 5210 nM
The estimate for compound 4 lay 2.1-fold (0.32 log units) below the measured number; the measured number falls inside the stated range.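

In this assay, nitro in place of benzamido on an aromatic carbon gives an at least 1.9-fold lower number from compound 3 to compound 4 (0.28 log units; that floor lies within the scatter), so this change alone cannot be called a gain. Going by these compounds, compound 3 stands at a limit and not a number, so the true size of that step stays unknown: the limit of > 10000 nM in this assay, at which 1 of the 4 values shown sits. The firmer reading comes from nitro in place of methoxy at the same place, which gives a 3.1-fold higher number from compound 2 to compound 4 (0.49 log units; beyond the scatter), so losing benzamido does not by itself bring the number back to that of compound 2, and the group that enters matters here.

On these data alone, how an amine or a carboxylic acid at this place would compare with methoxy and nitro remains open. For the compounds shown here, with only two numbers and one limit at this place, no ordering beyond these compounds can be claimed.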